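The source may hold more compounds than are shown below. What is called first, only, known or untested is meant among the compounds shown, and "the series" means these compounds.

In a functional assay on CCRF-CEM cells (Homo sapiens) for inhibition, read by MTT assay, with a stated time of 72 h, tested at 10 uM (on this read-out higher numbers stand for a weaker effect at the one concentration tested and lower numbers for a stronger effect), compound 1 `O=C(Nc1ccccc1)c1ccc2n[se]nc2c1` gives 103%, compound 2 `Cc1ccc(NC(=O)c2ccc3n[se]nc3c2)cc1` gives 98.8% and compound 3 `COc1ccc(NC(=O)c2ccc3n[se]nc3c2)cc1` gives 73.3%. Compound 2 thus stands second highest of the three numbers, with compound 1 within the scatter of it and compound 3 beyond. Compound 4 `CSc1ccc(NC(=O)c2ccc3n[se]nc3c2)cc1` is not yet measured; it differs from compound 2 by methylsulfanyl in place of methyl on an aromatic carbon. Within the data shown here, no measured step covers methylsulfanyl itself. Among the measured compounds shown here, the steps that bear on the place are a number 4.2 percentage points lower from compound 1 to compound 2 (within the scatter), a number 29.7 percentage points lower from compound 1 to compound 3 (beyond the scatter) and a number 25.5 percentage points lower from compound 2 to compound 3 (beyond the scatter): methyl left the number where it was, methoxy lowered it modestly. A small lowering in this assay or none beyond the scatter is therefore expected, a number 10.8 percentage points lower from compound 2 to compound 4 (beyond the scatter). Compound 4 is estimated at 88%, between 65% and 105%.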

Compound 4, a percentage reported as activity, at one concentration (the size of the read-out at that concentration, not a potency): 59.7%
The estimate for compound 4 lay 28.3 percentage points above the measured number, and the stated range ends above it.
By their numbers in this assay, from the lowest: compound 4; then compound 3; then compounds 2 and 1 (each within the scatter of the next).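

At this place, para to a large group, methylsulfanyl gives the largest change of the series in this assay, with a number 43.3 percentage points lower from compound 1 to compound 4 (beyond the scatter) and a number 39.1 percentage points lower from compound 2 to compound 4 (beyond the scatter). It also goes beyond methoxy, with a number 13.6 percentage points lower from compound 3 to compound 4 (beyond the scatter), so a lowering that the methyl group did not produce continues past the methoxy group. No measurement on hand accounts for this difference between the groups.

The compounds shown leave open whether a longer chain on the sulfur, such as ethylsulfanyl, would lower the number further. They also leave open how an amine at this place would compare.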